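Naphthyl for methoxyphenyl on the pyrazoline imine carbon

The compounds below may be only part of what the source reports. "The series", "measured", "known", "first", "only" and "open" are said of these compounds alone.

Three compounds of the shared core have numbers in a functional assay on cells (Leukemia cell, Homo sapiens) for cytotoxicity, read by sulforhodamine B assay, with a stated time of 48 h; on this read-out lower numbers stand for stronger inhibition of growth and higher numbers for weaker inhibition of growth. Compound 1 `COc1ccc(C2CC(c3ccccc3)=NN2C2=NC(=O)/C(=C3\C(=O)Nc4ccccc43)S2)cc1` gives 20800 nM, compound 2 `COc1ccc(C2=NN(C3=NC(=O)/C(=C4\C(=O)Nc5ccccc54)S3)C(c3ccc(OC)cc3)C2)cc1` gives 100000 nM and compound 3 `COc1ccc(C2=NN(C3=NC(=O)/C(=C4\C(=O)Nc5ccc(Br)cc54)S3)C(c3ccc(OC)cc3)C2)cc1` gives 62700 nM. Compound 2 stands highest of the three: a 1.6-fold lower number from compound 2 to compound 3 (0.20 log units; within the scatter), and a 4.8-fold higher number from compound 1 to compound 2 (0.68 log units; beyond the scatter).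

Compound 4 `COc1ccc(C2CC(c3ccc4ccccc4c3)=NN2C2=NC(=O)/C(=C3\C(=O)Nc4ccccc43)S2)cc1` differs from compound 2 by naphthalen-2-yl in place of 4-methoxyphenyl on a carbon with a double bond to nitrogen. Going by the values given here, only the step from compound 1 to compound 2 bears on this place, and it went up when methoxy entered; the bromo step concerns another ring. Among the compounds with values here, removing the methoxy is therefore expected to lower the number, though naphthalen-2-yl has no measured precedent here. The estimate for compound 4 in this assay is 30000 nM, within 10000 nM to 100000 nM, an expected 3.3-fold lower number from compound 2 to compound 4 (0.52 log units; beyond the scatter).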

Compound 4, concentration for total growth inhibition: 59600 nM
Compound 4: the middle estimate sits 2.0-fold (0.30 log units) below what was measured; the range from low to high includes it.
By their numbers in this assay, from the lowest: compound 1; then compounds 4, 3 and 2 (each within the scatter of the next).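

In this assay, naphthalen-2-yl and 4-methoxyphenyl on the carbon with a double bond to nitrogen are not separated (a 1.7-fold lower number from compound 2 to compound 4 (0.22 log units; within the scatter)). Phenyl at this place stays apart from naphthalen-2-yl as well as from 4-methoxyphenyl (a 2.9-fold higher number from compound 1 to compound 4 (0.46 log units; beyond the scatter)), so the two substituted or extended aryl groups read alike and only compound 1 stands out among the three compounds that differ here. Nothing at hand accounts for these steps. On these data alone, whether an amine, a carboxylic acid or a small alkyl such as methyl at this place would fall below compound 1 remains open.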